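The compounds below may be only part of what the source reports. "The series", "measured", "known", "first", "only" and "open" are said of these compounds alone.

Of the compounds shown here, two built on a shared core have been measured so far in a functional assay on MDA-MB-435 cells (Homo sapiens) for inhibition, read by sulforhodamine B assay, with a stated time of 48 h; a lower number here means a stronger inhibitor, a higher number a weaker inhibitor. There, compound 1 (`COc1ccc(N(C)c2nc(C)nc3c2CCC3)cc1`) gives 7 nM and compound 2 (`CSc1ccc(N(C)c2ncnc3c2CCC3)cc1`) gives 42.8 nM. Compound 2 therefore holds the higher of the two numbers, which makes it the weaker inhibitor of the pair, and the gap lies beyond the usual scatter of repeated measurements. These two compounds differ in more than one place, so their gap cannot be tied to any single change.

Compound 3 (`CCOc1ccc(N(C)c2ncnc3c2CCC3)cc1`) has not yet been measured. It comes from compound 2 by one swap: ethoxy in place of methylsulfanyl on an aromatic carbon, para to a large group (ethoxy in place of methylsulfanyl on an aromatic carbon). Within the data shown here, no measured pair shows what this swap does, so the expectation rests on little, and compound 2 at 42.8 nM is the natural starting point. In this assay, only a small rise within the scatter is expected, and the estimated change is a 1.4-fold higher number from compound 2 to compound 3 (0.15 log units; within the scatter). For compound 3 the expected value is 60 nM, with an estimated range from 15 nM to 250 nM.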

Compound 3, half-maximal inhibitory concentration: 48.7 nM
The estimate for compound 3 lay 1.2-fold (0.09 log units) above the measured number, and the stated range covers the measured number.
By their numbers in this assay, from the lowest: compound 1; then compounds 2 and 3 (each within the scatter of the next).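

In this assay, among these compounds, the swap at this position gives a 1.1-fold higher number from compound 2 to compound 3 (0.06 log units; within the scatter), which is the first reading of a single change on this aromatic carbon, para to a large group. The two numbers cannot be told apart, so for this pair, ethoxy with its 3 heavy atoms and methylsulfanyl with its 2 heavy atoms, joined to the ring through oxygen and sulfur in turn, read alike in this test. Nothing on hand explains why these two groups give such similar numbers.

Compound 2 and compound 3 each differ from compound 1, which gives 7 nM, in more than one place, so that lower number cannot be traced to this position or to any other single feature. Among the compounds shown here, this one step compares only two groups at this position, so it remains open whether a much longer chain such as butoxy, an amine or a carboxylic acid would also read alike there or would move the number beyond the scatter.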